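The compounds below may be only part of what the source reports. "The series", "measured", "known", "first", "only" and "open" are said of these compounds alone.

Measured compounds:
- compound 1 `CC(C)n1cc(-c2ccnc3[nH]c(C4CCNCC4)cc23)ccc1=O`: 910000 nM
- compound 2 `CN(C)C(=O)CN1CCC(c2cc3c(-c4ccc(=O)n(C5CCOCC5)c4)ccnc3[nH]2)CC1`: 840000 nM
- compound 3 `COc1cc(F)ccc1-c1ccnc2[nH]c(C3CCOCC3)cc12`: 97000 nM

Of the compounds shown here, three have been measured in a physicochemical assay for solubility, in phosphate buffer, at pH 7.4; a lower number here means a less soluble compound, a higher number a more soluble compound. Compound 1 gives 910000 nM, the highest of the three numbers. Compound 2 gives 840000 nM, which sits within the scatter of compound 1. Compound 3 gives 97000 nM, a number clearly below the other two; compound 3 carries neither the pyridinone nor the amine-bearing ring of the other two, so its values alone show nothing about a single change.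

Compound 4 `CNC(=O)CN1CCC(c2cc3c(-c4ccc(=O)n(C(C)C)c4)ccnc3[nH]2)CC1` is not yet measured in this assay. Relative to compound 1 the change is (methylcarbamoyl)methyl in place of hydrogen on an amine nitrogen in a ring. Compound 2 carries a related group on the same ring nitrogen, along with a second change elsewhere, and its value 840000 nM lies within the scatter of compound 1. For the measured compounds named here, no single-point step is available for this series, so the expectation rests on that comparison alone. The step of a 1.3-fold lower number from compound 1 to compound 4 (0.10 log units; within the scatter) is expected to be small, at most a modest decrease, and likely within the scatter. Compound 4 is therefore estimated at 720000 nM, in the range 320000 nM to 1100000 nM.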

Compound 4, solubility: 34000 nM
For compound 4 the middle estimate is 21-fold (1.33 log units) above the measured one, and the stated range ends above it.
By their numbers in this assay, from the lowest: compound 4; then compound 3; then compounds 2 and 1 (each within the scatter of the next).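

In this assay, for the compounds shown here, (methylcarbamoyl)methyl in place of hydrogen on an amine nitrogen in a ring gives a 27-fold lower number from compound 1 to compound 4 (1.43 log units; beyond the scatter), the first step that can be read as a change in one place. This shows that the amine nitrogen in the ring is not a neutral place in this read-out: a single substituent there moves the number far beyond the scatter, which compound 2 could not show, since it differs from compound 1 in more than one place. Nothing at hand accounts for the size of this step.

The compounds shown leave open which part of the entering group goes with the lower number: a plain methyl on the same nitrogen, a carboxylic acid on the same short chain, or a longer chain ending in the same amide would each separate the effect of substituting the nitrogen from that of the amide itself. Going by these compounds alone, also open is whether the step keeps its size on a compound that differs from compound 1 elsewhere, as only one such pair is available.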